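The source may report more compounds than this note shows. Statements on the series, on what has been measured and on what is new or still open speak of the compounds shown alone.

Measured so far:
compound 1, `CCCSc1nc(Cl)c2c(n1)N(Cc1ccccc1)C(C(=O)N1CCN(Cc3ccccc3)CC1)N2`: 14400 nM
compound 2, `CCCSc1nc(Cl)c2c(n1)N(Cc1cccs1)C(C(=O)N1CCN(C)CC1)N2`: 6420 nM

In a functional assay on A549 cells (Homo sapiens) for antiproliferative activity, read by MTT assay, with a stated time of 72 h (a higher number here means a weaker inhibitor, a lower number a stronger inhibitor), compound 1 gives 14400 nM. In this assay compound 2 gives 6420 nM, the lower of the two numbers shown, and its gap to compound 1 lies beyond the usual scatter. Compound 1 and compound 2 differ from each other in more than one place, so nothing beyond their two values can be read from that pair.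

Compound 3, `CCCSc1nc(Cl)c2c(n1)N(CC1CCCCC1)C(C(=O)N1CCN(C)CC1)N2`, remains to be measured. It differs from compound 2 by cyclohexyl in place of thiophen-2-yl on a saturated chain carbon bound to a nitrogen on an aromatic ring in a ring. Among the compounds with values here, no measured pair shows this change, so the size of the step is open; a move of modest size in either direction, or none beyond the scatter, is equally conceivable. The estimate for compound 3 in this assay is 7000 nM, with a range of 2500 nM to 20000 nM. The expected step is a 1.1-fold higher number from compound 2 to compound 3 (0.04 log units; within the scatter), judged likely to stay close to the scatter.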

Compound 3, half-maximal inhibitory concentration: 13200 nM
Estimate against measurement, compound 3: 1.9-fold (0.28 log units) below; the range from low to high includes it.
By their numbers in this assay, from the lowest: compound 2; then compounds 3 and 1 (each within the scatter of the next).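

Within the data shown here, this is the first comparison that differs in one place only: in this assay, cyclohexyl in place of thiophen-2-yl on a saturated chain carbon bound to a nitrogen on an aromatic ring in a ring gives a 2.1-fold higher number from compound 2 to compound 3 (0.31 log units; beyond the scatter). The position is therefore not indifferent to the ring it carries, and of this pair, compound 2 with its thiophen-2-yl holds the lower number, though the step is modest. No measurement shown here accounts for the step.

This one step cannot separate the loss of the sulfur from the change from an aromatic to a non-aromatic ring. From the compounds shown here alone, how a furan-2-yl ring, a pyridine ring or a longer chain at this position would read stays open, as does whether the step holds with another group on the piperazine.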